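Changing the Aryl Group on a Sulfonyl Sulfur

This account rests on a few compounds, and the source may have more. Where it says the series, first, only, none or still open, it means among the compounds named here.

Three compounds were measured in an assay on HeLa cells for displacement of a labelled ligand from 5-hydroxytryptamine receptor 6 (Homo sapiens); on this read-out lower numbers stand for stronger inhibition and higher numbers for weaker inhibition:

Compound 1 `CN1CCN(c2ccc3[nH]nc(S(=O)(=O)c4ccccc4Cl)c3c2)CC1`: 4 nM
Compound 2 `COc1cccc(S(=O)(=O)c2n[nH]c3ccc(N4CCN(C)CC4)cc23)c1`: 1.1 nM
Compound 3 `CN1CCN(c2ccc3[nH]nc(S(=O)(=O)c4c(Cl)cccc4Cl)c3c2)CC1`: 2.6 nM

Compound 3 stands second highest of the three numbers; the step of a 1.5-fold lower number from compound 1 to compound 3 (0.19 log units; within the scatter) lies within the scatter, while the step of a 2.4-fold higher number from compound 2 to compound 3 (0.37 log units; beyond the scatter) is modest but beyond it. Compound 4 `COc1ccc(S(=O)(=O)c2n[nH]c3ccc(N4CCN(C)CC4)cc23)cc1` differs from compound 3 in one place: 4-methoxyphenyl in place of 2,6-dichlorophenyl on a sulfonyl sulfur. For the measured compounds named here, two measured steps bear on this change. The step of a 2.4-fold higher number from compound 2 to compound 3 (0.37 log units; beyond the scatter) and the step of a 3.6-fold lower number from compound 1 to compound 2 (0.56 log units; beyond the scatter) both show a methoxyphenyl group giving a modestly lower number than a chlorophenyl group, although neither tests a 4-methoxyphenyl group, so the size is uncertain. Compound 4 is therefore expected to show a modest lowering, a 1.7-fold lower number from compound 3 to compound 4 (0.24 log units; within the scatter). The estimate for compound 4 in this assay is 1.5 nM, with a range from 0.6 nM to 4 nM.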

Compound 4, inhibition constant: 12 nM
Compound 4: middle estimate off by 8.0-fold (0.90 log units), on the low side; the whole stated range lies below it.
By their numbers in this assay, from the lowest: compound 2; then compounds 3 and 1 (each within the scatter of the next); then compound 4.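

In this assay, the methoxyphenyl group does not lower the number as such: an 11-fold higher number from compound 2 to compound 4 (1.04 log units; beyond the scatter) when 4-methoxyphenyl replaces 3-methoxyphenyl on the sulfonyl sulfur. The 4-methoxyphenyl group also reads worse than both chlorophenyl groups, with a 4.6-fold higher number from compound 3 to compound 4 (0.66 log units; beyond the scatter) and a 3.0-fold higher number from compound 1 to compound 4 (0.48 log units; beyond the scatter) so the earlier advantage over chlorophenyl holds only for 3-methoxyphenyl. No evidence here accounts for this difference. Left open is how a 4-chlorophenyl or 3-aminophenyl group on the sulfonyl sulfur would compare, and so whether this loss is confined to the 4-methoxyphenyl group.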